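A few compounds are considered here, and "the series" means these few. Any claim that something is new, unique, unknown or untested is made for them only; others in the source may bear on it.

The three measured compounds share one core and differ only in the group carried on the five-membered aromatic ring with three nitrogens. Compound 1 `Cc1ccc(S(=O)(=O)NCc2cn(C[C@H](O)[C@H]3OC(=O)C(OCc4ccccc4)=C3OCc3ccccc3)nn2)cc1` gives 16800 nM in a functional assay on A549 cells (Homo sapiens) for antiproliferative activity, read by MTT assay, with a stated time of 72 h; a lower number here means a stronger inhibitor, a higher number a weaker inhibitor. Compound 2 `O=C1O[C@H]([C@@H](O)Cn2cc(CNS(=O)(=O)c3ccc(Cl)cc3F)nn2)C(OCc2ccccc2)=C1OCc1ccccc1` gives 39100 nM in this assay, a change of a 2.3-fold higher number from compound 1 to compound 2 (0.37 log units; beyond the scatter). Compound 3 `COc1ccccc1-c1cn(C[C@H](O)[C@H]2OC(=O)C(OCc3ccccc3)=C2OCc2ccccc2)nn1` reaches only the limit of this assay, > 100000 nM, and so no number is known for it. The step of an at least 5.9-fold higher number from compound 1 to compound 3 (0.77 log units; beyond the scatter) is therefore open-ended, and compound 3 stands at the upper edge of the measured range, as one of the values sitting at the limit of > 100000 nM in this assay, at which 1 of the 3 values shown sits.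

Compound 4 `O=C1O[C@H]([C@@H](O)Cn2cc(CCCCl)nn2)C(OCc2ccccc2)=C1OCc1ccccc1` carries 3-chloropropyl in place of 2-methoxyphenyl on an aromatic carbon. Neither measured step contains a 3-chloropropyl, and both ran from compound 1 toward higher numbers, so nothing measured points to a recovery in this assay. The expectation is that compound 4 lands near the limit again, with no step beyond the scatter, so that an at least 1.4-fold lower number from compound 3 to compound 4 (0.15 log units; that floor lies within the scatter) is estimated. Compound 4 is thus expected to give about 70000 nM in this assay, somewhere between 20000 nM and 250000 nM.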

Compound 4, half-maximal inhibitory concentration: 29000 nM
Compound 4: the middle estimate sits 2.4-fold (0.38 log units) above what was measured; low and high end bracket the measured number.
By their numbers in this assay, from the lowest: compounds 1, 4 and 2 (each within the scatter of the next, the first and the last beyond it). At a limit, above all of these: compound 3.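

In this assay, replacing 2-methoxyphenyl with 3-chloropropyl on this aromatic carbon brings back a measurable number, a change of an at least 3.4-fold lower number from compound 3 to compound 4 (0.53 log units; beyond the scatter). Compound 3 itself remains a limit of the assay and not a number: the limit of > 100000 nM in this assay, at which 1 of the 4 values shown sits. The sulfonyl amino groups of the two earlier compounds are not required for activity at this level, since the simple chloroalkyl chain cannot be told apart from either, with a 1.3-fold lower number from compound 2 to compound 4 (0.13 log units; within the scatter) and a 1.7-fold higher number from compound 1 to compound 4 (0.24 log units; within the scatter).

On these data alone, what a plain propyl, a longer chain or an amine in place of the chlorine would give remains open, so the part played by the chlorine itself is unknown. Also open, as far as these compounds go, is whether any group at this position can reach numbers well below those of compound 1, compound 2 and compound 4.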